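Replacing the Anilino Group of Compound 2

A few compounds are considered here, and "the series" means these few. Any claim that something is new, unique, unknown or untested is made for them only; others in the source may bear on it.

Of the three compounds measured in a functional assay on NCI-H460 cells (Homo sapiens) for antiproliferative activity, read by CCK-8 assay, with a stated time of 72 h, tested at 2 uM (a lower number here means a weaker effect, a higher number a stronger effect of the compound at the concentration tested), compound 2 `Nc1ccccc1NC(=O)c1ccc(Cn2cnc3c(Nc4ccccc4)nc(Cl)nc32)cc1` stands highest with 42.7%. Compound 3 `CCCCn1cnc2c(Nc3ccccc3)nc(NCOCc3ccc(/C=C/C(=O)Nc4ccccc4N)cc3)nc21` gives 23.1% in this assay, and compound 1 `CC(C)n1cnc2c(Nc3ccccc3)nc(NCOCc3ccc(C(=O)Nc4ccccc4N)cc3)nc21` gives 15%, both gaps to compound 2 lying beyond the scatter. Compound 4 `CC1CCN(c2nc(Cl)nc3c2ncn3Cc2ccc(C(=O)Nc3ccccc3N)cc2)CC1` differs from compound 2 in one place: 4-methylpiperidin-1-yl in place of anilino on an aromatic carbon. Within the data shown here, no measured pair shows this exchange, so the data give no direct guide to its size or direction. A moderate step is expected, with a modest decrease slightly more likely than a rise, since one donor is lost while the count of heavy atoms is unchanged. Compound 4 is therefore expected to give 35% in this assay, within 15% to 55%. That estimate implies an expected step of a number 7.7 percentage points lower from compound 2 to compound 4 (within the scatter).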

Compound 4, a percentage reported as inhibition, at one concentration (the size of the read-out at that concentration, not a potency): 11.8%
For compound 4 the middle estimate is 23.2 percentage points above the measured one; the whole stated range lies above it.
By their numbers in this assay, from the lowest: compounds 4, 1 and 3 (each within the scatter of the next, the first and the last beyond it); then compound 2.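

In this assay, among these compounds, the first single exchange at this aromatic carbon, 4-methylpiperidin-1-yl in place of anilino, gives a number 30.9 percentage points lower from compound 2 to compound 4 (beyond the scatter), a large step although the count of heavy atoms stays the same. The exchange removes the hydrogen-bond donor and the aromatic ring of carbon only together, and nothing available separates these two changes or accounts for the result.

From the compounds shown here alone, it remains open whether a cyclohexylamino group or a benzylamino group would keep the value of compound 2 at this carbon. Going by these compounds, it also remains open whether a step of this size would recur with another group in place of the chloro group.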